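A few compounds are considered here, and "the series" means these few. Any claim that something is new, unique, unknown or untested is made for them only; others in the source may bear on it.

The measured compounds, each with its result in a functional assay on SK-OV-3 cells (Homo sapiens) for antiproliferative activity, read by MTT assay, with a stated time of 72 h; on this read-out lower numbers stand for stronger inhibition and higher numbers for weaker inhibition:

compound 1, `C#Cc1cccc(NC(=O)CCc2cccc3c2B(O)OC3)c1`, 980 nM
compound 2, `Cc1cc(C)c(NC(=O)CCc2cccc3c2B(O)OC3)c(C)c1`, 19000 nM
compound 3, `O=C(CCc1cccc2c1B(O)OC2)Nc1cccc(-c2cccc(Cl)c2)c1`, 300 nM

All three share the same core and the same amide linker; they differ only in what is attached at the far end. Compound 3 gives the lowest number of the three. Its nearest neighbour is compound 1: a 3.3-fold lower number from compound 1 to compound 3 (0.51 log units; beyond the scatter). Compound 2, at 19000 nM, sits far above compound 3 at 300 nM.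

Compound 4, `N#Cc1cccc(-c2cccc(NC(=O)CCc3cccc4c3B(O)OC4)c2)c1`, differs from compound 3 by a single swap: cyano in place of chloro on an aromatic carbon. For the measured compounds named here, only one measured step touches this part of the molecule, the one from ethynyl to 3-chlorophenyl, a 3.3-fold lower number from compound 1 to compound 3 (0.51 log units; beyond the scatter), and it exchanges a small group for a whole ring. Going by the values given here, no measured pair swaps one small substituent for another on the 3-chlorophenyl, so there is no direct precedent for chloro to cyano. The expectation is therefore a step of modest size at most, most likely within the usual scatter, with the direction uncertain. Compound 4 is expected to give about 450 nM in this assay, within a range of 150 nM to 1400 nM, which would mean a 1.5-fold higher number from compound 3 to compound 4 (0.18 log units; within the scatter).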

Compound 4, half-maximal inhibitory concentration: 120 nM
For compound 4 the middle estimate is 3.8-fold (0.57 log units) above the measured one, and the stated range ends above it.
By their numbers in this assay, from the lowest: compound 4; then compound 3; then compound 1; then compound 2.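

Even a swap of one small group for another on the 3-chlorophenyl ring moves the result: cyano in place of chloro gives a 2.5-fold lower number from compound 3 to compound 4 (0.40 log units; beyond the scatter) in this assay, so among these compounds the outcome depends on what the added ring carries and not only on the ring being there. Starting from the ethynyl group of compound 1, the 3-cyanophenyl group gives an 8.2-fold lower number from compound 1 to compound 4 (0.91 log units; beyond the scatter) and the 3-chlorophenyl group gives a 3.3-fold lower number from compound 1 to compound 3 (0.51 log units; beyond the scatter), which means the same ring can produce steps of clearly different size, depending on the single substituent placed meta to the large group. Nothing at hand explains why cyano gives the lower number here.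

On these data alone, whether other groups at this place, such as an amine, a methoxy group or a carboxylic acid, would lower the number further or raise it again remains open. Also open, as far as these compounds go, is whether cyano would give a similar result at another place on the same ring, and whether the trend would hold with a longer chain between the amide and the shared core.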